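The compounds below may be only part of what the source reports. "The series", "measured", "known", "first", "only" and "open" are said of these compounds alone.

Compound 1 `Cc1cc(/C=C/C(=O)O)cc(C)c1Oc1ccc([N+](=O)[O-])c(Nc2ccc(C#N)cc2)n1` and compound 3 `Cc1cc(/C=C/C(=O)O)cc(C)c1Oc1ccc(N)c(Nc2ccc(C#N)cc2)n1` share one core and differ in a single place. In an ADME assay on MT2 cells (Homo sapiens) for cytotoxicity, read by XTT assay, with a stated time of 4 days (on this read-out lower numbers stand for higher toxicity in this test and higher numbers for lower toxicity in this test), compound 1 gives 34800 nM, and compound 3 gives 15700 nM. The change between them is amino in place of nitro on an aromatic carbon, and the step is a 2.2-fold lower number from compound 1 to compound 3 (0.35 log units; beyond the scatter). Compound 2 `CC(=O)/C=C/c1cc(C)c(Oc2cc(Nc3ccc(C#N)cc3)c([N+](=O)[O-])cc2[N+](=O)[O-])c(C)c1` is built on a different core, and how the two cores differ is not broken down here. In this assay compound 2 gives only a limit, > 100000 nM, a value that sits at the limit of > 100000 nM in this assay, at which 1 of the 3 values shown sits. Compound 4 `CC(=O)/C=C/c1cc(C)c(Oc2cc(Nc3ccc(C#N)cc3)c(N)cc2[N+](=O)[O-])c(C)c1` remains to be measured in this assay; it differs from compound 2 by amino in place of nitro on an aromatic carbon. Within the data shown here, this is the same kind of change as the one from compound 1 to compound 3, though the surroundings are not identical: in compound 1 the carbon belongs to a six-membered aromatic ring with 1 nitrogen and lies two atoms from the ring nitrogen, whereas in compound 2 it belongs to a six-membered aromatic ring of carbon only and lies meta to a nitro group. The value of compound 2 is only a limit, and the starting point for compound 4 is not a number. A step of an at least 1.6-fold lower number from compound 2 to compound 4 (0.22 log units; that floor lies within the scatter) is expected for compound 4, resting on a 2.2-fold lower number from compound 1 to compound 3 (0.35 log units; beyond the scatter). Compound 4 is therefore estimated at 60000 nM, between 30000 nM and 150000 nM.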

Compound 4, half-maximal cytotoxic concentration: 22600 nM
Compound 4: the middle estimate sits 2.7-fold (0.42 log units) above what was measured; the whole stated range lies above it.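

In this assay, amino in place of nitro lowers the number on both cores, and the new step is an at least 4.4-fold lower number from compound 2 to compound 4 (0.64 log units; beyond the scatter). Set side by side, the change keeps its direction in these two pairs, and the comparison reads: the same change on two cores in this assay, a 2.2-fold lower number (0.35 log units; beyond the scatter) from compound 1 to compound 3 and an at least 4.4-fold lower number (0.64 log units; beyond the scatter) from compound 2 to compound 4; the limit leaves it open whether they differ. The starting point of compound 2 is a limit and not a number, so the data show only that the direction held in these two pairs, not whether the size of the step carries from one core to the other: the limit of > 100000 nM in this assay, at which 1 of the 4 values shown sits.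

The compounds shown leave open how other groups in place of the nitro would read on either core, for instance a methylamino group, an acetamide or a hydroxyl group. Among these compounds, they also leave open whether the step on the core of compound 2 depends on the nitro group that remains in compound 4, as no pair shows the change with that group replaced by a hydrogen or a methoxy group.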